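A few compounds are considered here, and "the series" means these few. Any claim that something is new, unique, unknown or untested is made for them only; others in the source may bear on it.

Working notes on a short hydrazide series built on one shared core. Compound 1 `COc1cc(/C=N/NC(=O)CCN2CCN(c3ccnc4cc(Cl)ccc34)CC2)ccc1O` and compound 2 `O=C(CCN1CCN(c2ccnc3cc(Cl)ccc23)CC1)N/N=C/c1c[nH]c2ccccc12` each carry an aromatic group on the carbon with a double bond to nitrogen, while compound 3 `NNC(=O)CCN1CCN(c2ccnc3cc(Cl)ccc23)CC1` ends in the bare hydrazide. In a physicochemical assay for inhibition, read by spectrophotometry, with a stated time of 24 h, tested at 2.5 mM (on this read-out higher numbers stand for more inhibition at the one concentration tested (going by the name of the read-out) and lower numbers for less inhibition), compound 1 gives 50.7%, compound 2 gives 43.3% and compound 3 gives 21.7%. Compound 3 thus holds the lowest of the three numbers, with compound 2 nearest and compound 1 furthest, both separated from it beyond the scatter. The two substituted compounds lie within the scatter of each other (a number 7.4 percentage points lower from compound 1 to compound 2 (within the scatter)).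

Compound 4 `O=C(CCN1CCN(c2ccnc3cc(Cl)ccc23)CC1)N/N=C/c1ccccc1Cl` differs from compound 3 in one place: a group of 9 heavy atoms (7 carbon, 1 nitrogen, 1 chlorine; one six-membered aromatic ring of carbon only) in place of one nitrogen atom, on an amide-type nitrogen. The measured steps bearing on this are the two removals of an aromatic group from the amide-type nitrogen, a number 29 percentage points lower from compound 1 to compound 3 (beyond the scatter) and a number 21.6 percentage points lower from compound 2 to compound 3 (beyond the scatter), each modest and beyond the scatter. Putting an aromatic group back at the same place is therefore expected to raise the read-out by a step of comparable size, and compound 4 is expected to show a number 23.3 percentage points higher from compound 3 to compound 4 (beyond the scatter) in this assay. The estimate for compound 4 in this assay is 45%, with a range from 30% to 60%.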

Compound 4, a percentage reported as inhibition, at one concentration (the size of the read-out at that concentration, not a potency): 87.3%
Estimate against measurement, compound 4: 42.3 percentage points below; the measured number lies above the stated range.
By their numbers in this assay, from the lowest: compound 3; then compounds 2 and 1 (each within the scatter of the next); then compound 4.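

Compound 1 and compound 2 suggested that the aromatic group on the carbon with a double bond to nitrogen mattered little once present, but 2-chlorophenyl changes that picture: in this assay it gives a number 44 percentage points higher from compound 2 to compound 4 (beyond the scatter) in place of 1H-indol-3-yl and a number 36.6 percentage points higher from compound 1 to compound 4 (beyond the scatter) in place of 4-hydroxy-3-methoxyphenyl. Replacing the amino group on the amide-type nitrogen gives a number 65.6 percentage points higher from compound 3 to compound 4 (beyond the scatter), a step printed as large where the two earlier steps to the bare hydrazide were modest, so the size of the gain depends on which aromatic group is carried and not merely on one being present. Nothing at hand bears on why the 2-chlorophenyl compound stands apart from the other two aromatic compounds.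

Whether the chlorine or the ring carrying it accounts for the step remains open, and a plain phenyl group, or a methyl group or bromine in place of the chlorine, would separate the two. From the compounds shown here alone, the numbers also stand at a single concentration and give no potency, so the standing of the compounds at other concentrations remains open.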